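Cyclohexyl Out, Pyridin-4-yl In: An Expected Setback

This account rests on a few compounds, and the source may have more. Where it says the series, first, only, none or still open, it means among the compounds named here.

Compound 1 `CC(=O)N1CCCC1(CCc1ccccc1)C(=O)OCc1ccccc1` gives 8000 nM in an in vitro functional assay on Hep cells for antagonist activity at solute carrier family 12 member 5 (Rattus norvegicus), with a stated time of 10 min; on this read-out lower numbers stand for stronger inhibition and higher numbers for weaker inhibition.
Compound 2 `CC(=O)N1CCCC1(CC1CCCCC1)C(=O)OCc1ccccc1` gives 1000 nM in this assay.

The two measured compounds share one core and differ only in the group attached on a saturated chain carbon bound to a saturated ring carbon. Among the compounds with values here, putting cyclohexyl in place of benzyl there gives an 8.0-fold lower number from compound 1 to compound 2 (0.90 log units; beyond the scatter), so compound 2 holds the lower of the two numbers, with compound 1 the only other point of comparison.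

Compound 3 `CC(=O)N1CCCC1(Cc1ccncc1)C(=O)OCc1ccccc1` takes the next step: pyridin-4-yl in place of cyclohexyl on a saturated chain carbon bound to a saturated ring carbon. Within the data shown here, this reverses the direction of the only measured change: the saturated six-membered ring leaves and an aromatic six-membered ring returns, this time carrying one nitrogen. The step that bears on it, an 8.0-fold lower number from compound 1 to compound 2 (0.90 log units; beyond the scatter), shows the number falling when the aromatic ring was removed, so the number is expected to rise again by about a 10-fold higher number from compound 2 to compound 3 (1.00 log units; beyond the scatter). Compound 3 is therefore estimated at 10000 nM in this assay, with a range from 3000 nM to 40000 nM. What the added nitrogen does is untested among these compounds.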

Compound 3, half-maximal inhibitory concentration: 2000 nM
For compound 3 the middle estimate is 5.0-fold (0.70 log units) above the measured one; the measured number lies below the stated range.
By their numbers in this assay, from the lowest: compounds 2 and 3 (each within the scatter of the next); then compound 1.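

On a saturated chain carbon bound to a saturated ring carbon, pyridin-4-yl in place of cyclohexyl gives a 2.0-fold higher number from compound 2 to compound 3 (0.30 log units; within the scatter) in this assay and so leaves the two groups level on this read-out, which means that an aromatic ring in this place does not by itself bring back the weaker number of compound 1. That could not be told from the first pair alone, where the loss of an aromatic ring and the better number came together. Pyridin-4-yl in place of benzyl gives a 4.0-fold lower number from compound 1 to compound 3 (0.60 log units; beyond the scatter) as a modest but real gain, so compound 1 stands apart from the other two whether the ring in compound 2 or the ring in compound 3 takes this place, and no measurement at hand explains why.

Still open, going by these compounds, is what the ring nitrogen of pyridin-4-yl contributes, which a plain phenyl ring in its place would help to separate from the effect of simply having an aromatic ring, while pyridin-3-yl would test where that nitrogen sits. Also open, on these data alone, is how far this place tolerates something quite different, such as an amine or a carboxylic acid.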